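This account rests on a few compounds, and the source may have more. Where it says the series, first, only, none or still open, it means among the compounds named here.

Compound 1 `O=C(CCc1ccccc1)Nc1nc2ccccc2c(=O)s1`: 422 nM
Compound 2 `COc1cccc(CCC(=O)Nc2nc3ccccc3c(=O)s2)c1`: 367 nM
Compound 3 `O=C(COc1cccc(Cl)c1)Nc1nc2ccccc2c(=O)s1`: a limit, > 10000 nM

In an assay on membranes from brain for displacement of a labelled ligand from adenosine receptor A1 (Rattus norvegicus), read by scintillation counting, with a stated time of 90 min (a lower number here means a stronger inhibitor, a higher number a weaker inhibitor), compound 2 gives 367 nM. Of the two numeric values shown, compound 2 stands alongside compound 1, which gives 422 nM; the step of a 1.1-fold lower number from compound 1 to compound 2 (0.06 log units; within the scatter) lies within the scatter. Compound 3 returns only a limit, > 10000 nM (the limit of > 10000 nM in this assay, at which 1 of the 3 values shown sits). Compound 4 `O=C(CCc1ccccc1Br)Nc1nc2ccccc2c(=O)s1` differs from compound 2 by 2-bromophenyl in place of 3-methoxyphenyl on a saturated chain carbon, two bonds along the chain from a carbonyl carbon. Going by the values given here, the single measured step, a 1.1-fold lower number from compound 1 to compound 2 (0.06 log units; within the scatter), concerns a methoxy on the aromatic ring and was within the scatter; no measured step covers a bromine or this position of the ring. Compound 4 is therefore expected to give a number close to compound 2, a step of a 1.4-fold higher number from compound 2 to compound 4 (0.13 log units; within the scatter), with an estimate of 500 nM and a range from 180 nM to 1500 nM.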

Compound 4, inhibition constant: > 10000 nM
Compound 4: a limit, no number; the forecaster's own chance of this, stated with the estimate: 10%; middle value at least 20-fold (1.30 log units) away from the limit.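

Bromine on the ring at this end of the chain is not tolerated as methoxy was: the change brings an at least 23-fold higher number from compound 1 to compound 4 (1.37 log units; beyond the scatter), and the swap of groups brings an at least 27-fold higher number from compound 2 to compound 4 (1.43 log units; beyond the scatter). Going by these compounds alone, the only earlier step on this ring, a 1.1-fold lower number from compound 1 to compound 2 (0.06 log units; within the scatter), lay within the scatter, so it gave no sign that this ring could respond so sharply to a change. Both new steps rest on a limit, not a number, so their full size is unknown: the limit of > 10000 nM in this assay, at which 2 of the 4 values shown sit.

Whether the bromine itself or its place on the ring accounts for the step stays open. Also open, going by these compounds, is how a chlorine, a methyl or an amine on this ring would read in this assay.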